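The compounds below may be only part of what the source reports. "The series", "measured", "known", "first", "only" and "open" are said of these compounds alone.

Of the compounds shown here, two have been tested so far, both sharing one core. Compound 1 `CN1C[C@@H](c2cccs2)[C@@]2(Cc3ccccc3C2=O)[C@@]12C(=O)Nc1ccccc12` carries a thiophen-2-yl group on a saturated ring carbon, and compound 2 `CN1C[C@@H](c2ccco2)[C@@]2(Cc3ccccc3C2=O)[C@@]12C(=O)Nc1ccccc12` carries a furan-2-yl group at the same place. In a functional assay on the whole organism (strain Wister albino) for inhibition, with Rattus norvegicus as the target, read by paw edema, with a stated time of 1 h, at a dose of 50 mg/kg by the intraperitoneal route (on this read-out higher numbers stand for more inhibition at the one dose given (going by the name of the read-out) and lower numbers for less inhibition), compound 1 gives 49.9%, and compound 2 gives 48.8%. For the measured compounds named here, the only step seen so far, a number 1.1 percentage points lower from compound 1 to compound 2 (within the scatter), shows that swapping these two five-membered aromatic rings changes nothing that can be told apart from noise, so compound 1 stands alongside compound 2 with the two values inside the usual scatter of each other.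

Compound 3 `CN1C(=O)[C@@]2(c3ccccc31)N(C)C[C@@H](c1cccs1)[C@@]21Cc2ccccc2C1=O` has not been measured. It differs from compound 1 in one place: methyl in place of hydrogen on an amide-type nitrogen in a ring. No measured step touches this amide-type nitrogen, so nothing shown speaks for or against a change there, and the one available step is itself within the scatter. On that basis the step of a number 1.9 percentage points lower from compound 1 to compound 3 (within the scatter) is expected to be no larger than the scatter. Compound 3 is therefore estimated at 48%, with a likely range from 35% to 60%.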

Compound 3, a percentage reported as inhibition, in the whole organism at one dose (the size of the read-out at that dose, not a potency): 33%
Compound 3: middle estimate off by 15 percentage points, on the high side; measured number outside the range, below it.
By their numbers in this assay, from the lowest: compound 3; then compounds 2 and 1 (each within the scatter of the next).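

Compared with the earlier step, this one shows that the ring nitrogen matters in a way the aromatic ring swap did not. In this assay, methyl in place of hydrogen on this amide-type nitrogen gives a number 16.9 percentage points lower from compound 1 to compound 3 (beyond the scatter), which lies beyond the scatter, while furan-2-yl in place of thiophen-2-yl gives a number 1.1 percentage points lower from compound 1 to compound 2 (within the scatter), which does not. A single added carbon at this position is therefore enough to lower the read-out, although compound 3 still shows a clear reading of 33%, so the inhibition is reduced and not lost. No measurement shown here accounts for this drop, so the reason for it remains unknown.

The compounds shown do not reveal whether what counts is losing the amide hydrogen or adding the methyl group, nor whether an ethyl group, a benzyl group or a longer chain ending in a carboxylic acid on this nitrogen would lower the number further, match compound 3 or restore the level of compound 1. They also leave open whether the same methyl change would have a similar effect on compound 2, which carries furan-2-yl in place of thiophen-2-yl.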